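Swapping 2,4-difluorobenzyl for propyl in compound 4

The source may report more compounds than this note shows. Statements on the series, on what has been measured and on what is new or still open speak of the compounds shown alone.

In a functional assay on Bel-7402 cells (Homo sapiens) for antiproliferative activity, read by MTT assay, with a stated time of 72 h (on this read-out lower numbers stand for stronger inhibition and higher numbers for weaker inhibition), compound 3 `C=C1C(=O)O[C@H]2[C@H]1CC/C(COC(=O)Cn1cc(F)c(=O)n(Cc3ccc(F)cc3F)c1=O)=C\CC[C@@]1(C)O[C@@H]21` gives 3670 nM as its reading, and compound 2 `C=C1C(=O)O[C@H]2[C@H]1CC/C(COC(=O)Cn1cc(F)c(=O)n(Cc3ccccc3)c1=O)=C\CC[C@@]1(C)O[C@@H]21` gives 3980 nM as its reading, so the two sit within the scatter of each other. For compound 1 `C=C1C(=O)O[C@H]2[C@H]1CC/C(COC(=O)CCC(=O)OCn1cc(F)c(=O)[nH]c1=O)=C\CC[C@@]1(C)O[C@@H]21` the assay returned only the limit > 20000 nM and no number.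

The move to compound 4 `C=C1C(=O)O[C@H]2[C@H]1CC/C(COC(=O)Cn1cc(F)c(=O)n(CCC)c1=O)=C\CC[C@@]1(C)O[C@@H]21` is ethyl in place of 2,4-difluorophenyl on a saturated chain carbon bound to an aromatic nitrogen and puts ethyl in place of 2,4-difluorophenyl on a saturated chain carbon bound to an aromatic nitrogen. Within the data shown here, one measured step bears on this place: 2,4-difluorophenyl in place of phenyl gave a 1.1-fold lower number from compound 2 to compound 3 (0.04 log units; within the scatter) and so made no visible difference. Among the measured compounds shown here, that step trades one aromatic ring for another, whereas here the ring leaves, and no measured step shows such a loss. With compound 3 at 3670 nM as the starting point, a modest rise in the number is expected in this assay with a 1.6-fold higher number from compound 3 to compound 4 (0.21 log units; within the scatter) as the estimated step, held with little confidence. For compound 4 the estimated value is 6000 nM with an expected range from 2500 nM to 16000 nM in this measurement.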

Compound 4, half-maximal inhibitory concentration: 8580 nM
Compound 4: middle estimate off by 1.4-fold (0.16 log units), on the low side; the range from low to high includes it.
By their numbers in this assay, from the lowest: compounds 3 and 2 (each within the scatter of the next); then compound 4. At a limit, above all of these: compound 1.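

Ethyl in place of the aromatic ring, on a saturated chain carbon bound to an aromatic nitrogen, is the first change at this place to move the number beyond the scatter in this assay: it gives a 2.3-fold higher number from compound 3 to compound 4 (0.37 log units; beyond the scatter) and a 2.2-fold higher number from compound 2 to compound 4 (0.33 log units; beyond the scatter). The two fluorines alone made no visible difference, with a 1.1-fold lower number from compound 2 to compound 3 (0.04 log units; within the scatter), so among these three compounds losing the ring counts for more than changing its substituents, though the loss is only modest. Nothing measured here bears on why the number rises.

On these data alone, it remains open whether an aromatic ring as such is needed at this place, or whether a cyclohexyl ring or a longer chain would serve as well. As far as these compounds go, whether an amine at the end of the chain would be tolerated also remains open.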